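Shared core series: aryl to cyclohexylmethyl exchange

The source may hold more compounds than are shown below. What is called first, only, known or untested is meant among the compounds shown, and "the series" means these compounds.

compound 1 `CCCOc1ccc(C2(c3ccc(O)cc3)C(=O)Nc3c2ccc(F)c3F)cc1`: > 1000 nM
compound 2 `COc1ccc(C2(c3cccc(O)c3)C(=O)Nc3c2ccc(F)c3F)cc1`: 145 nM
compound 3 `O=C1Nc2c(ccc(F)c2F)C1(c1ccc(O)cc1)c1ccc(F)c(F)c1`: 19 nM

In a functional assay on PC-3 cells (Homo sapiens) for cytotoxicity, read by WST assay, with a stated time of 72 h (on this read-out lower numbers stand for stronger inhibition and higher numbers for weaker inhibition), compound 3 gives 19 nM, the lowest of the two numbers shown; compound 2 sits at a higher number, beyond the scatter. For compound 1 the assay reports only a limit, not a number, (the limit of > 1000 nM in this assay, at which 1 of the 3 values shown sits).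

Compound 4 `O=C1Nc2c(ccc(F)c2F)C1(CC1CCCCC1)c1ccc(O)cc1` has not yet been measured. It differs from compound 3 in one place: cyclohexylmethyl in place of 3,4-difluorophenyl on a saturated ring carbon. The one six-membered aromatic ring of carbon only gives way to a six-membered non-aromatic ring of carbon only, attached through a chain.

Within the data shown here, no measured pair shows a change of this kind, so the expected step is uncertain. The expectation is a rise in number beyond the scatter, a 7.9-fold higher number from compound 3 to compound 4 (0.90 log units; beyond the scatter). Compound 4 is estimated at 150 nM, within 30 nM to 800 nM.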

Compound 4, half-maximal inhibitory concentration: > 1000 nM
Compound 4 gave a limit, no number; the forecaster's own chance of this, stated with the estimate: 20%; middle value at least 6.6-fold (0.82 log units) from the limit.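

In this assay, among these compounds, cyclohexylmethyl in place of 3,4-difluorophenyl on a saturated ring carbon gives an at least 52-fold higher number from compound 3 to compound 4 (1.72 log units; beyond the scatter), the only step that can be read so far. This position therefore does not treat the two six-membered carbon rings alike. Compound 4 gives only a limit, not a number: the limit of > 1000 nM in this assay, at which 2 of the 4 values shown sit.

As far as these compounds go, whether the rise follows the change of ring or the added chain stays open; directly attached cyclohexyl and benzyl would separate the two. From the compounds shown here alone, how an amine or a carboxylic acid would read at this position also stays open.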